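Three measured compounds and an untested pyrimidinyl analogue

The source may report more compounds than this note shows. Statements on the series, on what has been measured and on what is new or still open speak of the compounds shown alone.

Compound 1, `Cc1ccc(N2CCN(C(=S)SCc3ccc4nc(N)nc(N)c4c3)CC2)cc1`, gives 2190 nM in a functional assay on A549 cells (Homo sapiens) for antiproliferative activity, read by MTT assay, with a stated time of 72 h; on this read-out higher numbers stand for weaker inhibition and lower numbers for stronger inhibition.
Compound 2, `Nc1nc(N)c2cc(CSC(=S)N3CCN(c4ccc(Cl)cc4)CC3)ccc2n1`, gives 5210 nM in this assay.
Compound 3, `Nc1nc(N)c2cc(CSC(=S)N3CCN(c4ccccc4Cl)CC3)ccc2n1`, gives 3610 nM in this assay.

Compound 3 sits second highest of the three numbers; its nearest neighbour is compound 2, a 1.4-fold lower number from compound 2 to compound 3 (0.16 log units; within the scatter), and its furthest is compound 1, a 1.6-fold higher number from compound 1 to compound 3 (0.22 log units; within the scatter). Both of those steps stay within the scatter, so compound 3 cannot be ranked against either. Among the compounds with values here, the only step that leaves the scatter is a 2.4-fold higher number from compound 1 to compound 2 (0.38 log units; beyond the scatter), a modest one.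

The untested compound 4, `Nc1nc(N)c2cc(CSC(=S)N3CCN(c4ncccn4)CC3)ccc2n1`, differs from compound 3 in a single place: pyrimidin-2-yl in place of 2-chlorophenyl on an amine nitrogen in a ring.

Within the data shown here, none of the measured steps tests an aromatic ring with hetero atoms on the ring nitrogen; all three steps swap or move a substituent on a carbon-only ring, and two of them fall within the scatter. The available evidence therefore gives no ground for a large movement in this assay, and a step of no more than the scatter, if anything toward a slightly higher number, is expected.

Compound 4 is estimated at 4500 nM in this assay, with a range from 1800 nM to 11000 nM, which means an expected step of a 1.2-fold higher number from compound 3 to compound 4 (0.10 log units; within the scatter).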

Compound 4, half-maximal inhibitory concentration: 4010 nM
The estimate for compound 4 lay 1.1-fold (0.05 log units) above the measured number, within the range that was stated.
By their numbers in this assay, from the lowest: compounds 1, 3, 4 and 2 (each within the scatter of the next, the first and the last beyond it).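

In this assay, within the data shown here, the ring nitrogen now carries an aromatic ring with hetero atoms, and this change produces no step that can be told from the scatter, whichever carbon-only ring it replaces: the steps are a 1.1-fold higher number from compound 3 to compound 4 (0.05 log units; within the scatter) and a 1.3-fold lower number from compound 2 to compound 4 (0.11 log units; within the scatter) and a 1.8-fold higher number from compound 1 to compound 4 (0.26 log units; within the scatter) and all three stay within it. Pyrimidin-2-yl brings two hydrogen-bond acceptors and two ring nitrogen atoms where 2-chlorophenyl has none, so at this place, among these four compounds, that difference leaves the number within the scatter, while the only step beyond it remains a 2.4-fold higher number from compound 1 to compound 2 (0.38 log units; beyond the scatter) between two carbon-only rings. No measurement shown bears on what lies behind this flat result.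

The compounds shown leave open whether pyrimidin-2-yl stands for aromatic rings with hetero atoms in general, since a pyridin-2-yl or thiazol-2-yl group on the same ring nitrogen would test that. They also leave open whether a group without an aromatic ring, such as cyclohexyl or a plain ethyl chain, would hold the number in this range or move it beyond the scatter.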